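The source may report more compounds than this note shows. Statements on the series, on what has been measured and on what is new or still open speak of the compounds shown alone.

Measured so far:
compound 1 `CC(C)(C)N(NC(=O)c1ccc(Br)cc1)C(=O)c1ccccc1Cl` with 33.9 nM
compound 2 `COc1ccc(C(=O)NN(C(=O)c2ccccc2Cl)C(C)(C)C)cc1` with 51.3 nM

Both compounds were tested in an assay on cells for agonist activity at ecdysone receptor (Bombyx mori), read by a luciferase reporter, with a stated time of 24 h; a lower number here means that less compound is needed, a higher number that more compound is needed for the effect. Going by the values given here, compound 2 holds the higher of the two numbers, yet the one step that connects them, a 1.5-fold higher number from compound 1 to compound 2 (0.18 log units; within the scatter), is within the scatter, so on these data the two cannot be told apart. Compound 3 `Cc1ccc(C(=O)NN(C(=O)c2ccccc2Cl)C(C)(C)C)c(C)c1` is not yet measured. It differs from compound 2 in one place: 2,4-dimethylphenyl in place of 4-methoxyphenyl on a carbonyl carbon. Among the compounds with values here, only one measured step touches this part of the shared core, namely a 1.5-fold higher number from compound 1 to compound 2 (0.18 log units; within the scatter), and it stayed within the scatter. Within the data shown here, that step is the sole guide here, and it points to no change beyond the scatter, so for compound 3 the expected step is a 1.1-fold higher number from compound 2 to compound 3 (0.03 log units; within the scatter). Compound 3 is therefore estimated at 55 nM in this assay, with a range from 18 nM to 170 nM, the width reflecting that no other measured change at this position is known.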

Compound 3, half-maximal effective concentration: 162 nM
Beside the measured number, compound 3's estimate is 2.9-fold (0.47 log units) below it, and the stated range covers the measured number.
By their numbers in this assay, from the lowest: compounds 1 and 2 (each within the scatter of the next); then compound 3.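

In this assay this place on the carbonyl carbon proves sensitive to what sits there: 2,4-dimethylphenyl gives a 3.2-fold higher number from compound 2 to compound 3 (0.50 log units; beyond the scatter) against 4-methoxyphenyl and a 4.8-fold higher number from compound 1 to compound 3 (0.68 log units; beyond the scatter) against 4-bromophenyl. Going by these compounds alone, both steps are modest but beyond the scatter, so this is the first change that the assay can clearly tell apart, whereas bromo and methoxy could not be separated. Nothing available explains why more of compound 3 is needed.

The compounds shown leave open whether the rise goes with one methyl group of 2,4-dimethylphenyl, with both, or with the loss of the methoxy oxygen. They also leave open how a simple 4-methylphenyl group, or a ring carrying an amine or a carboxylic acid, would behave at this place.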